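Halogen swap on aryl triazenes: cytotoxicity working notes

A few compounds are considered here, and "the series" means these few. Any claim that something is new, unique, unknown or untested is made for them only; others in the source may bear on it.

Compound 1 `Clc1cccc(/N=N/N2CCCCC2)c1` and compound 2 `Brc1cccc(/N=N/N2CCCCC2)c1` share one core; compound 3 `Clc1ccc(/N=N/N2CCCC2)cc1` and compound 4 `Brc1ccc(/N=N/N2CCCC2)cc1` share another, and the difference between the two cores is not broken down here. In an ADME assay on MDBK cells (Bos taurus) for cytotoxicity, read by MTT assay, with a stated time of 96 h (a higher number here means that more compound is tolerated, a lower number that less compound is tolerated), compound 1 gives > 100000 nM, which is a limit. In this assay compound 2 gives > 100000 nM, also a limit. In this assay compound 3 gives > 100000 nM, again a limit. The change bromo in place of chloro on an aromatic carbon produced a step that the two limits leave unreadable from compound 1 to compound 2, both values sitting at the limit of > 100000 nM in this assay, at which 3 of the 3 values shown sit. The change bromo in place of chloro on an aromatic carbon is the same kind of change, though the place is para to a group of 7 heavy atoms rather than meta to a group of 8 heavy atoms. Going by the values given here, because the limit of > 100000 nM in this assay, at which 3 of the 3 values shown sit, holds every value so far, compound 4 is expected to show a step that the limit leaves unreadable from compound 3 to compound 4. The estimate for compound 4 is 120000 nM, ranging from 50000 nM to 300000 nM.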

Compound 4, half-maximal cytotoxic concentration: > 100000 nM
Compound 4: no number, only a limit; the forecaster's own chance of this, stated with the estimate: 85%; the middle value does not contradict the limit.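

No step can be read from compound 3 to compound 4 in this assay, as both values are limits: the limit of > 100000 nM in this assay, at which 4 of the 4 values shown sit. The compounds shown leave open whether bromo in place of chloro changes tolerance at all.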